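This account rests on a few compounds, and the source may have more. Where it says the series, first, only, none or still open, it means among the compounds named here.

Measured so far:
compound 1, `Cc1cc(C(=O)O)nn1Cc1cc(Br)ccc1OCc1ccccc1`: 6.31 nM
compound 2, `Cc1cc(C(=O)O)nn1C(C)c1cc(Cl)ccc1OCc1ccccc1`: 10 nM
compound 3, `Cc1cc(C(=O)Nc2ccc(F)cc2)nn1Cc1cc(Cl)ccc1OCc1ccccc1`: 79.4 nM

All three values come from an assay on CHO-K1 cells for displacement of a labelled ligand from prostaglandin E2 receptor EP1 subtype (Homo sapiens); on this read-out higher numbers stand for weaker inhibition and lower numbers for stronger inhibition. Compound 1 and compound 2 both carry a carboxylic acid on the shared core; compound 3 carries an amide there instead and stands highest of the three numbers, beyond the scatter against either of them. Compound 4, `Cc1cc(NC(=O)CC(C)(C)C)nn1Cc1cc(Cl)ccc1OCc1ccccc1`, is not yet measured. Its change from compound 3 is (neopentylcarbonyl)amino in place of (4-fluorophenyl)carbamoyl on an aromatic carbon. Among the measured compounds shown here, no step between measured compounds covers this change, so the expectation rests on compound 3 alone. A modest step toward weaker inhibition is expected, a 1.9-fold higher number from compound 3 to compound 4 (0.28 log units; within the scatter), possibly within the scatter. For compound 4 the expected value in this assay is 150 nM, in the range 40 nM to 600 nM.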

Compound 4, half-maximal inhibitory concentration: 10 nM
Compound 4: middle estimate off by 15-fold (1.18 log units), on the high side, and the stated range ends above it.
By their numbers in this assay, from the lowest: compounds 1, 2 and 4 (each within the scatter of the next); then compound 3.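

In this assay, placing (neopentylcarbonyl)amino instead of (4-fluorophenyl)carbamoyl on this aromatic carbon gives a 7.9-fold lower number from compound 3 to compound 4 (0.90 log units; beyond the scatter), so this position responds to the change and stronger inhibition does not depend on the six-membered aromatic ring of the group that leaves. Among the compounds shown here, the single step cannot separate loss of that ring from the change in how the amide is attached to the core. No supporting data account for the step. Open, on these data alone, is whether a plain amine or an acetylamino group on this carbon would hold the number of compound 4.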